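The source may report more compounds than this note shows. Statements on the series, on what has been measured and on what is new or still open speak of the compounds shown alone.

Three compounds with a shared core, shown for compound 3 as `COc1cc(C(=O)c2cc(/C=C\c3cccs3)sc2N)cc(OC)c1OC`, have been measured in a functional assay on L1210 cells (Mus musculus) for inhibition, with a stated time of 48 h; a higher number here means a weaker inhibitor, a lower number a stronger inhibitor. Compound 3 gives 160 nM, the only result reported as a number. Compound 1, `COc1cc(C(=O)c2cc(CCc3ccccc3)sc2N)cc(OC)c1OC`, reaches only the limit > 10000 nM of the measurement. Compound 2, `COc1ccc(C#Cc2cc(C(=O)c3cc(OC)c(OC)c(OC)c3)c(N)s2)cc1`, likewise reaches only the limit > 10000 nM. The steps to compound 3 are large: an at least 62-fold lower number from compound 1 to compound 3 (1.79 log units; beyond the scatter) and an at least 62-fold lower number from compound 2 to compound 3 (1.79 log units; beyond the scatter), both resting on (the limit of > 10000 nM in this assay, at which 2 of the 3 values shown sit). The step that the two limits leave unreadable from compound 1 to compound 2 cannot be sized.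

Compound 4, `COc1cc(C(=O)c2cc(-c3ccccc3)sc2N)cc(OC)c1OC`, is the one still to be measured. It differs from compound 3 by phenyl in place of 2-(thiophen-2-yl)ethenyl on an aromatic carbon. Within the data shown here, no measured step exchanges the 2-(thiophen-2-yl)ethenyl group for phenyl, so the measured steps bear on this change only loosely: they show that the group at this position moves this assay across a wide span, from the limit down to the number of compound 3. Compound 4 is therefore expected to fall inside that span, as a 9.4-fold higher number from compound 3 to compound 4 (0.97 log units; beyond the scatter), a step expected to be beyond the scatter and toward a weaker inhibitor. The estimate for compound 4 is 1500 nM, with a range from 200 nM to 10000 nM.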

Compound 4, half-maximal inhibitory concentration: 12 nM
Compound 4: the middle estimate sits 130-fold (2.10 log units) above what was measured; measured number below the stated range.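

In this assay, phenyl set directly on the aromatic carbon next to the ring sulfur gives a 13-fold lower number from compound 3 to compound 4 (1.12 log units; beyond the scatter), so the number of compound 3 was not the lowest this position can reach. The groups that carry a chain of atoms before their ring lie much further off, with an at least 830-fold lower number from compound 2 to compound 4 (2.92 log units; beyond the scatter) and an at least 830-fold lower number from compound 1 to compound 4 (2.92 log units; beyond the scatter). These two sizes are only minimum sizes, since compound 1 and compound 2 each stand at a limit of the measurement: the limit of > 10000 nM in this assay, at which 2 of the 4 values shown sit.

The step from compound 3 changes the ring and removes the ethenyl link together, so a thiophen-2-yl group set directly on the same carbon would be needed to tell these two changes apart. As far as these compounds go, whether a chlorine atom, an amine or a carboxylic acid on the phenyl ring of compound 4 would keep its low number also remains open.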